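The compounds below may be only part of what the source reports. "The series", "measured", "known", "first", "only" and "open" are said of these compounds alone.

Of the compounds shown here, three on the shared core have been measured in a functional assay on KB cells (Homo sapiens) for cytotoxicity; a lower number here means a stronger inhibitor, a higher number a weaker inhibitor: compound 1 `CCCCOC1=CC(=O)c2ccccc2C1=O` gives 27000 nM, compound 2 `CCOC1=CC(=O)c2ccccc2C1=O` gives 16900 nM, and compound 3 `O=C1C=C(Oc2cccs2)C(=O)c2ccccc21` gives 41500 nM. The standing of the thiophen-2-yl compound is set by two steps: a 1.5-fold higher number from compound 1 to compound 3 (0.19 log units; within the scatter) and a 2.5-fold higher number from compound 2 to compound 3 (0.39 log units; beyond the scatter).

Compound 4 `O=C1C=C(Oc2ccco2)C(=O)c2ccccc21` carries one change, furan-2-yl in place of thiophen-2-yl on an oxygen on an unsaturated carbon. For the measured compounds named here, no measured step covers this exchange directly. The nearest evidence is the two steps above, made on the same oxygen. Exchanging ethyl in compound 2 for thiophen-2-yl gave only a 2.5-fold higher number from compound 2 to compound 3 (0.39 log units; beyond the scatter), and that exchange alters the group far more than swapping one five-membered aromatic ring for another.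

No step beyond the scatter is therefore expected in this assay, with at most a slight drift towards the values of compound 1 and compound 2. The expected step is a 1.3-fold lower number from compound 3 to compound 4 (0.10 log units; within the scatter). The estimate for compound 4 is 33000 nM, with an expected range from 15000 nM to 70000 nM.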

Compound 4, half-maximal inhibitory concentration: 53400 nM
Beside the measured number, compound 4's estimate is 1.6-fold (0.21 log units) below it; the range from low to high includes it.
By their numbers in this assay, from the lowest: compounds 2, 1, 3 and 4 (each within the scatter of the next, the first and the last beyond it).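

In this assay, for the compounds shown here, furan-2-yl in place of thiophen-2-yl on this oxygen gives a 1.3-fold higher number from compound 3 to compound 4 (0.11 log units; within the scatter), the first direct exchange of one five-membered aromatic ring for another here, and it does not separate the two rings. Against the ethyl group, the furan-2-yl ring gives a 3.2-fold higher number from compound 2 to compound 4 (0.50 log units; beyond the scatter), so a second ring now stands apart from ethyl, while against the butyl group it gives a 2.0-fold higher number from compound 1 to compound 4 (0.30 log units; within the scatter), so the butyl group stands apart from neither ring. No measurement is at hand that could account for these steps.

Open, from the compounds shown here alone, is whether a phenyl or pyridyl ring on this oxygen would stay in the same range. Also open, going by these compounds, is whether a chain ending in an amine or a carboxylic acid would move the number further than ethyl, butyl or either five-membered ring.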